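Changing the amide partner on a diaryl aminothiophene core

The compounds below may be only part of what the source reports. "The series", "measured", "known", "first", "only" and "open" are said of these compounds alone.

Measured so far in a functional assay on PC-3 cells (Homo sapiens) for inhibition, read by sulforhodamine B assay, with a stated time of 72 h; on this read-out higher numbers stand for weaker inhibition and lower numbers for stronger inhibition:
- compound 1 `Nc1sc(-c2ccc(Cl)cc2)c(-c2ccc(Cl)cc2)c1C(=O)N1CCCCC1` gives 14300 nM
- compound 2 `CC1CN(C(=O)c2c(N)sc(-c3ccc(Cl)cc3)c2-c2ccc(Cl)cc2)CCN1` gives 7210 nM
- compound 3 `Nc1sc(-c2ccc(Cl)cc2)c(-c2ccc(Cl)cc2)c1C(=O)Nc1ccccc1` gives only a limit, > 50000 nM

Compound 2 holds the lowest of the two numbers; its nearest neighbour is compound 1, and the step of a 2.0-fold lower number from compound 1 to compound 2 (0.30 log units; within the scatter) stays within the scatter. Compound 4 `CCCCNC(=O)c1c(N)sc(-c2ccc(Cl)cc2)c1-c1ccc(Cl)cc1` is not yet measured; it differs from compound 2 as butylamino in place of 3-methylpiperazin-1-yl on a carbonyl carbon. The measured steps that bear on it both replace a ring amine with anilino: an at least 6.9-fold higher number from compound 2 to compound 3 (0.84 log units; beyond the scatter) and an at least 3.4-fold higher number from compound 1 to compound 3 (0.54 log units; beyond the scatter), each ending at the limit (the limit of > 50000 nM in this assay, at which 1 of the 3 values shown sits). Butylamino is likewise an open, single-hydrogen amine partner, so compound 4 is expected to give a higher number than compound 2 in this assay, by roughly a 2.2-fold higher number from compound 2 to compound 4 (0.35 log units; beyond the scatter). Compound 4 is estimated at 16000 nM, with a range of 5000 nM to 50000 nM.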

Compound 4, half-maximal inhibitory concentration: 17800 nM
Compound 4: middle estimate off by 1.1-fold (0.05 log units), on the low side, within the range that was stated.
By their numbers in this assay, from the lowest: compounds 2, 1 and 4 (each within the scatter of the next, the first and the last beyond it). At a limit, above all of these: compound 3.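

In this assay, an open-chain partner on this carbonyl carbon need not fall to the limit reached with anilino: the change of phenyl to butyl on the amide-type nitrogen gives an at least 2.8-fold lower number from compound 3 to compound 4 (0.44 log units; beyond the scatter). That step starts from a limit, not a number: the limit of > 50000 nM in this assay, at which 1 of the 4 values shown sits. Against the ring amines the picture differs, with a 2.5-fold higher number from compound 2 to compound 4 (0.39 log units; beyond the scatter) but a 1.2-fold higher number from compound 1 to compound 4 (0.10 log units; within the scatter), so replacing a ring amine with butylamino has no single outcome here.

From the compounds shown here alone, how a longer chain would read stays open. So does a butyl chain carrying an amine or a carboxylic acid.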